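The source may hold more compounds than are shown below. What is called first, only, known or untested is meant among the compounds shown, and "the series" means these compounds.

This account follows the step from compound 1 to compound 4. Compound 1 `O=C(/C=C/c1ccc(O)cc1)c1c(O)cccc1OCc1ccccc1` was tested in a functional assay on HCT-15 cells (Homo sapiens) for antiproliferative activity, read by sulforhodamine B assay; on this read-out lower numbers stand for stronger inhibition of growth and higher numbers for weaker inhibition of growth. In this assay compound 1 returns only a limit of the assay, > 30000 nM. Two further members of the series were measured alongside it. Compound 2 `CC(C)(C)CCOc1cccc(O)c1C(=O)/C=C/c1ccc(C(=O)O)cc1` gives 2170 nM in this assay. Compound 3 `CC(C)(C)CCOc1cccc(O)c1C(=O)CCc1ccc(O)cc1` also returns only a limit in this assay, > 30000 nM. Compound 1 thus sits at the limit of > 30000 nM in this assay, at which 2 of the 3 values shown sit, and only compound 2 shows a number at all.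

Compound 4 `CCCCOc1cccc(O)c1C(=O)/C=C/c1ccc(O)cc1` has not yet been measured in this assay. It differs from compound 1 in one place: propyl in place of phenyl on a saturated chain carbon bound to an oxygen on an aromatic ring. Among the measured compounds shown here, no step between two measured compounds differing in one place is available, so the size of this change has to be judged without a direct precedent. The step from compound 1 to compound 4 is expected to be modest, an at least 1.5-fold lower number from compound 1 to compound 4 (0.17 log units; that floor lies within the scatter). Compound 4 is therefore estimated to give about 20000 nM in this assay, within 5000 nM to 60000 nM, with a real chance that only a limit is reported again.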

Compound 4, concentration for 50% growth inhibition: > 30000 nM
Compound 4 gave a limit, no number (the forecaster's own chance of this, stated with the estimate: 50%); middle value at least 1.5-fold (0.17 log units) away from the limit.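

Compound 4, like compound 1, returns only a limit in this assay, so the step between these two compounds cannot be read: the limit of > 30000 nM in this assay, at which 3 of the 4 values shown sit.

The compounds shown leave open whether propyl in place of phenyl at this place changes growth inhibition at all, and by how much.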